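The source may report more compounds than this note shows. Statements on the series, on what has been measured and on what is new or still open speak of the compounds shown alone.

Among the compounds with values here, in a functional assay on PC-3 cells (Homo sapiens) for cytotoxicity, read by MTT assay, with a stated time of 48 h (on this read-out lower numbers stand for stronger inhibition and higher numbers for weaker inhibition), compound 1 `COc1ccc(-c2c(-c3cc(OC)c(OC)c(OC)c3)noc2N)cc1` gives 3030 nM, the only exact number so far. Compound 2 `COc1cc(-c2noc(N)c2-c2ccc(Cl)cc2)cc(OC)c1OC` is recorded only as a limit, > 50000 nM. Compound 3 `COc1ccc(-c2c(-c3cc(OC)c(OC)c(OC)c3)noc2NC(C)=O)cc1` differs from compound 1 by acetyl in place of hydrogen on a nitrogen on an aromatic ring. Within the data shown here, the single measured step, an at least 16-fold higher number from compound 1 to compound 2 (1.21 log units; beyond the scatter), is chloro in place of methoxy on an aromatic carbon, so it shows a large loss from one change but bears only indirectly on this nitrogen. The step expected in this assay is a 2.6-fold higher number from compound 1 to compound 3 (0.42 log units; beyond the scatter), a moderate move towards weaker inhibition. Compound 3 is estimated at 8000 nM, with an expected range of 2000 nM to 30000 nM.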

Compound 3, half-maximal inhibitory concentration: > 50000 nM
Compound 3 ended at the assay's limit; the forecaster's own chance of this, stated with the estimate: 20%; middle value at least 6.2-fold (0.79 log units) away from the limit.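

In this assay, amino to acetamido on the nitrogen brings an at least 16-fold higher number from compound 1 to compound 3 (1.21 log units; beyond the scatter), so a change at this nitrogen alone, and not only one on an aromatic carbon, is enough to lose the measurable inhibition of compound 1. Compound 3 stands at > 50000 nM, which is a limit of the assay and not a number. The full size of this step therefore cannot be read: the limit of > 50000 nM in this assay, at which 2 of the 3 values shown sit.

As far as these compounds go, whether the loss is specific to acetyl stays open. A methyl group or a longer chain on this nitrogen could tell whether the free amino group itself is needed.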